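Bicyclic amide substituents on the piperazine urea series

The source may report more compounds than this note shows. Statements on the series, on what has been measured and on what is new or still open speak of the compounds shown alone.

Three ureas share one core and differ only in the aromatic bicycle on the amide-type nitrogen. Compound 1 `O=C(Nc1cccc2nonc12)N1CCN(Cc2cccc(Oc3ccc(Cl)cc3)c2)CC1` gives 120 nM in an assay on isolated protein for inhibition of Fatty-acid amide hydrolase 1 (Rattus norvegicus), with a stated time of 60 min; on this read-out higher numbers stand for weaker inhibition and lower numbers for stronger inhibition. Compound 2 `Cc1nc2cc(NC(=O)N3CCN(Cc4cccc(Oc5ccc(Cl)cc5)c4)CC3)ccc2o1` gives 200 nM in this assay, and compound 3 `O=C(Nc1noc2ccccc12)N1CCN(Cc2cccc(Oc3ccc(Cl)cc3)c2)CC1` gives 8.1 nM in this assay. Compound 2 sits together with compound 1, the gap being a 1.7-fold higher number from compound 1 to compound 2 (0.22 log units; within the scatter), but far from compound 3, the gap being a 25-fold lower number from compound 2 to compound 3 (1.39 log units; beyond the scatter). Compound 4 `O=C(Nc1ccc2nccn2c1)N1CCN(Cc2cccc(Oc3ccc(Cl)cc3)c2)CC1` carries yet another bicycle: a group of 9 heavy atoms (7 carbon, 2 nitrogen; one five-membered aromatic ring with 2 hetero atoms, one six-membered aromatic ring with 1 hetero atom) in place of a group of 10 heavy atoms (8 carbon, 1 nitrogen, 1 oxygen; one five-membered aromatic ring with 2 hetero atoms, one six-membered aromatic ring of carbon only), on an amide-type nitrogen. Among the measured compounds shown here, no measured step exchanges a bicycle for one of this kind, so the bearing steps are indirect. The steps of a 15-fold lower number from compound 1 to compound 3 (1.17 log units; beyond the scatter) and a 25-fold lower number from compound 2 to compound 3 (1.39 log units; beyond the scatter) show that swapping the bicycle can move the number a great deal in one case, whereas a 1.7-fold higher number from compound 1 to compound 2 (0.22 log units; within the scatter) shows barely any movement in another. With both bicycles holding two hydrogen-bond acceptors and no donor, compound 4 is expected to land near compound 2, the expected step being a 1.3-fold lower number from compound 2 to compound 4 (0.12 log units; within the scatter), though with a broad range because a 25-fold lower number from compound 2 to compound 3 (1.39 log units; beyond the scatter) shows that large moves do occur. Compound 4 is therefore estimated at 150 nM, between 40 nM and 600 nM.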

Compound 4, half-maximal inhibitory concentration: 3600 nM
Compound 4: the middle estimate sits 24-fold (1.38 log units) below what was measured; measured number outside the range, above it.
By their numbers in this assay, from the lowest: compound 3; then compounds 1 and 2 (each within the scatter of the next); then compound 4.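

At this amide-type nitrogen, the same hydrogen-bond donor and acceptor counts do not keep the number in place in this assay: replacing 2-methyl-1,3-benzoxazol-5-yl with the bicycle carrying a hetero atom in its six-membered ring gives an 18-fold higher number from compound 2 to compound 4 (1.26 log units; beyond the scatter) on that change. The same entering group also gives a 30-fold higher number from compound 1 to compound 4 (1.48 log units; beyond the scatter) and a 440-fold higher number from compound 3 to compound 4 (2.65 log units; beyond the scatter) in the other two comparisons. The earlier steps therefore understated how far a bicycle swap can move the number here, and nothing measured accounts for this move.

Among the compounds shown here, whether the rise follows from the hetero atom in the six-membered ring or from the bicycle as a whole remains open, as no pair here changes one alone. Also open, on these data alone, is how a plain phenyl group on this nitrogen would compare, or an amine or carboxylic acid on the entering bicycle.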